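This account rests on a few compounds, and the source may have more. Where it says the series, first, only, none or still open, it means among the compounds named here.

Measured compounds:
Compound 1 `CNC(=O)c1c(-c2ccc(F)cc2)oc2cc(N(Cc3ccc(B(O)O)c(F)c3)S(C)(=O)=O)c(C3CC3)cc12`, which in an ADME assay on the whole organism (Rattus norvegicus) for pharmacokinetics, read by LC-MS, at a dose of 1 mg/kg by the intravenous route (a higher number here means faster removal of the compound, a lower number slower removal), gives 29 mL/min/kg.
Compound 2 `CNC(=O)c1c(-c2ccc(F)cc2)oc2cc(N3C(=O)OC[C@@H]3c3ccc(B(O)O)c(F)c3)c(C3CC3)cc12`, which in this assay gives 22 mL/min/kg.

Of these two numbers, compound 1 has the higher one, but compound 2 sits close to it, and the gap between the two falls within the usual scatter of this measurement, so nothing can be said about an order between them. Compound 3 `CNC(=O)c1c(-c2ccc(F)cc2)oc2cc(N(C3CCc4c(B(O)O)cccc43)S(C)(=O)=O)c(C3CC3)cc12` has not yet been measured in this assay. It differs from compound 1 in one place: a group of 12 heavy atoms (9 carbon, 1 boron, 2 oxygen; one five-membered non-aromatic ring of carbon only, one six-membered aromatic ring of carbon only) in place of a group of 11 heavy atoms (7 carbon, 1 boron, 2 oxygen, 1 fluorine; one six-membered aromatic ring of carbon only), on a sulfonamide nitrogen. The shared core, the amide, the cyclopropyl group and the methylsulfonyl group are unchanged; only the group carried on the sulfonamide nitrogen is exchanged, and the boronic acid remains part of it. Among the measured compounds shown here, no pair of measured compounds shows what such an exchange does in this assay, so there is no step to lean on, and the expectation is for no step beyond the scatter, in either direction. On that basis, the step from compound 1 to compound 3 is expected to be a 1.0-fold higher number from compound 1 to compound 3 (0.01 log units; within the scatter). Compound 3 is therefore estimated at 30 mL/min/kg, with a range from 15 mL/min/kg to 60 mL/min/kg.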

Compound 3, clearance: 69 mL/min/kg
Estimate against measurement, compound 3: 2.3-fold (0.36 log units) below, and the stated range ends below it.
By their numbers in this assay, from the lowest: compounds 2 and 1 (each within the scatter of the next); then compound 3.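

Among the compounds shown here, the group on the sulfonamide nitrogen matters in this assay: this exchange gives a 2.4-fold higher number from compound 1 to compound 3 (0.38 log units; beyond the scatter) and is the only step in this set, so this position is not indifferent to what it carries. The rise appears even though the boronic acid stays, the counts of hydrogen-bond donors and acceptors are the same in the group that leaves and the group that enters, and neither group has a net charge. What does change is that the fluorine leaves and a five-membered non-aromatic ring of carbon only enters, but nothing measured here explains why the number moves.

The compounds shown leave open which part of the exchange carries the step, as the loss of the fluorine and the arrival of the new ring occur together, and a group with the new ring and the fluorine kept would separate the two. Also open, going by these compounds, is what part the boronic acid plays in this result, and how the number would stand with a carboxylic acid in its place on the same group.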